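Adding fluoro to a phenyl of compound 1

The compounds below may be only part of what the source reports. "The series", "measured", "known", "first", "only" and "open" are said of these compounds alone.

In a functional assay on A549 cells (Homo sapiens) for antiproliferative activity, read by MTT assay, with a stated time of 48 h (a lower number here means a stronger inhibitor, a higher number a weaker inhibitor), compound 1 `Clc1ccc2[nH]c(-c3cn(-c4ccccc4)nc3-c3ccccc3)nc2c1` gives 2370 nM, compound 2 `COc1ccc2[nH]c(-c3cn(-c4ccccc4)nc3-c3ccccc3)nc2c1` gives 1230 nM and compound 3 `O=C(OCc1ccccc1)c1ccc2[nH]c(-c3cn(-c4ccccc4)nc3-c3ccccc3)nc2c1` gives 19300 nM. Compound 1 thus stands close to compound 2, with a 1.9-fold lower number from compound 1 to compound 2 (0.28 log units; within the scatter), and well away from compound 3, with an 8.1-fold higher number from compound 1 to compound 3 (0.91 log units; beyond the scatter). The remaining step is a 16-fold higher number from compound 2 to compound 3 (1.20 log units; beyond the scatter). Compound 4 `Fc1ccc(-c2nn(-c3ccccc3)cc2-c2nc3cc(Cl)ccc3[nH]2)cc1` carries fluoro in place of hydrogen on an aromatic carbon, fluoro in place of hydrogen on an aromatic carbon, phenyl to 4-fluorophenyl. All three measured steps change the group at the chloro place of compound 1, and none touches a phenyl, so they bear on this change only loosely. No step beyond the scatter is expected, and the estimated step is a 1.2-fold lower number from compound 1 to compound 4 (0.07 log units; within the scatter). For compound 4 the estimated value is 2000 nM, with an expected range of 800 nM to 5500 nM.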

Compound 4, half-maximal inhibitory concentration: 1320 nM
Compound 4: middle estimate off by 1.5-fold (0.18 log units), on the high side; measured number inside the range.
By their numbers in this assay, from the lowest: compounds 2, 4 and 1 (each within the scatter of the next); then compound 3.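

In this assay, going by these compounds alone, the step phenyl to 4-fluorophenyl gives a 1.8-fold lower number from compound 1 to compound 4 (0.25 log units; within the scatter), the first reading at a phenyl rather than at the chloro place of compound 1. This phenyl therefore accepts fluoro on an aromatic carbon, para to a large group, without a change beyond the scatter. No measurement here accounts for this result.

Still open, going by these compounds, is whether a larger group at this carbon, such as an amine or a carboxylic acid, would leave the number as little moved. The same question stands for the other phenyl of the shared core.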